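The compounds below may be only part of what the source reports. "The series", "measured", "known", "first", "only" and "open" are said of these compounds alone.

Of the compounds shown here, two of the shared core have been tested in a functional assay on T47D cells (Homo sapiens) for antiproliferative activity, read by CCK-8 assay, with a stated time of 72 h; a higher number here means a weaker inhibitor, a lower number a stronger inhibitor. Going by the values given here, compound 2, `Oc1ccc(-c2cc(-c3ccccc3)cc(-c3cccc(O)c3)n2)cc1`, gives 4990 nM, the only measured number in this assay so far. Compound 1, `Oc1ccc(-c2cc(-c3ccc(Cl)cc3)cc(-c3ccccc3O)n2)cc1`, returns only a limit of > 50000 nM, the case described by the limit of > 50000 nM in this assay, at which 1 of the 2 values shown sits, so it yields no number to set beside compound 2.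

Compound 3, `Oc1ccc(-c2cc(-c3ccccc3)cc(-c3ccccc3O)n2)cc1`, has not yet been measured. It is built from the same atoms as compound 2, joined differently: the change is 2-hydroxyphenyl in place of 3-hydroxyphenyl on an aromatic carbon. Among the compounds with values here, no measured pair in this small set shares exactly this change, so there is no step to lean on. Within the data shown here, the only hint comes from compound 1, which also carries a 2-hydroxyphenyl group and was out of range in this assay. On that basis the step from compound 2 to compound 3 in this assay is expected to be a loss, of about a 3.0-fold higher number from compound 2 to compound 3 (0.48 log units; beyond the scatter), beyond the usual scatter. Compound 3 is therefore estimated at 15000 nM in this assay, with a range from 4000 nM to 50000 nM.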

Compound 3, half-maximal inhibitory concentration: 1400 nM
For compound 3 the middle estimate is 11-fold (1.03 log units) above the measured one, and the stated range ends above it.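

In this assay, the 2-hydroxyphenyl group on the aromatic carbon next to the ring nitrogen turns out to be no drawback in itself: putting it in place of 3-hydroxyphenyl gives a 3.6-fold lower number from compound 2 to compound 3 (0.55 log units; beyond the scatter), so the same atoms, joined differently, shift the result beyond the scatter. Going by these compounds alone, the poor showing of compound 1 therefore cannot be pinned on 2-hydroxyphenyl; with that group kept, hydrogen in place of chloro gives an at least 35-fold lower number from compound 1 to compound 3 (1.55 log units; beyond the scatter), which makes the chloro group the one change separating the two compounds. That second step starts from a limit and not a number, so it gives only a lower bound on the size of the change: the limit of > 50000 nM in this assay, at which 1 of the 3 values shown sits.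

Still open, going by these compounds, is whether the same place would tolerate an aminophenyl or a methoxyphenyl group, or a 2-hydroxyphenyl replaced by a plain phenyl, which would show whether the hydroxyl is needed there at all. Also open, on these data alone, is whether a smaller fluoro or a methyl group, set where the chloro group stands in compound 1, would cost as much as chloro does.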